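Swapping Hydroxy for Nitro: Expectations for Compound 4

This account rests on a few compounds, and the source may have more. Where it says the series, first, only, none or still open, it means among the compounds named here.

Of the compounds shown here, three have been tested in a functional assay on A549 cells (Homo sapiens) for antiproliferative activity, read by sulforhodamine B assay, with a stated time of 48 h; on this read-out higher numbers stand for weaker inhibition and lower numbers for stronger inhibition. Compound 1 `COc1cc(OC)c2sc(-c3ccc(N/C=C\C(=O)c4cc(OC)c(OC)c(OC)c4)cc3)nc2c1` gives 21800 nM, and compound 2 `COc1ccc(C(=O)/C=C\Nc2ccc(-c3nc4cc(OC)c(OC)c(OC)c4s3)cc2)cc1[N+](=O)[O-]` gives 21200 nM. Compound 3 `COc1cc(OC)c2sc(-c3ccc(N/C=C\C(=O)c4ccc(OC)c(O)c4)cc3)nc2c1` gives 10600 nM, the lowest of the three numbers; its distance to compound 2 lies within the scatter, and only its distance to compound 1 lies beyond it, so it cannot be called clearly the strongest inhibitor.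

Compound 4 `COc1cc(OC)c2sc(-c3ccc(N/C=C\C(=O)c4ccc(OC)c([N+](=O)[O-])c4)cc3)nc2c1` is the next candidate. It differs from compound 3 in one place: nitro in place of hydroxy on an aromatic carbon.

Among the compounds with values here, the only step measured in one place is a 2.1-fold lower number from compound 1 to compound 3 (0.31 log units; beyond the scatter), a modest change on the same carbonyl-bearing aryl ring. Within the data shown here, no step has been measured for a nitro entering in place of a hydroxy. Compound 2 does carry the 4-methoxy-3-nitrophenyl group of compound 4, although on a different core, and its number stands within the scatter of compound 3. Taken together, these data give no reason to expect a step beyond the scatter in this assay for compound 4, though a slight drift toward a higher number is expected. Compound 4 is therefore estimated at 16000 nM, with a range of 7000 nM to 36000 nM, which is expected to amount to a 1.5-fold higher number from compound 3 to compound 4 (0.18 log units; within the scatter).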

Compound 4, half-maximal inhibitory concentration: 5800 nM
The estimate for compound 4 lay 2.8-fold (0.44 log units) above the measured number; measured number below the stated range.
By their numbers in this assay, from the lowest: compounds 4, 3, 2 and 1 (each within the scatter of the next, the first and the last beyond it).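

In this assay, the exchange at this aromatic carbon, ortho to a methoxy group, is now measured directly (a 1.8-fold lower number from compound 3 to compound 4 (0.26 log units; within the scatter)), and it shows that the hydroxy, with its hydrogen-bond donor, can give way to nitro without a step beyond the scatter. With the 4-methoxy-3-nitrophenyl group held constant, the methoxy on the core also proves to matter, since hydrogen in its place gives a step beyond the scatter (a 3.7-fold lower number from compound 2 to compound 4 (0.56 log units; beyond the scatter)), while the full exchange of 3,4,5-trimethoxyphenyl for 4-methoxy-3-nitrophenyl on the shared core likewise exceeds it (a 3.8-fold lower number from compound 1 to compound 4 (0.58 log units; beyond the scatter)). Nothing measured here accounts for any of these steps.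

The compounds shown leave open how an amine, a carboxylic acid or a nitrile at the same aromatic carbon would compare with hydroxy and nitro. They also leave open whether hydrogen in place of methoxy on the core would give a similar step with the 3-hydroxy-4-methoxyphenyl group, for which only one core is shown.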